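Longer amine arms on a shorter chain

The compounds below may be only part of what the source reports. "The series", "measured", "known", "first", "only" and "open" are said of these compounds alone.

In a functional assay on PC-3 cells (Homo sapiens) for antiproliferative activity, read by WST assay, with a stated time of 3 days (a higher number here means a weaker inhibitor, a lower number a stronger inhibitor), compound 1 `CCCN(CCC)CCCCCOc1c(-c2cc(OC)c(OC)c(OC)c2)oc2ccccc2c1=O` gives 2600 nM and compound 2 `CCCCN(CCCC)CCCCCOc1c(-c2cc(OC)c(OC)c(OC)c2)oc2ccccc2c1=O` gives 6800 nM as the higher, weaker of the two numbers. Compound 3 `CCCCCN(CCCCC)CCCCOc1c(-c2cc(OC)c(OC)c(OC)c2)oc2ccccc2c1=O` has dipentylamino in place of (dibutylamino)methyl on a saturated chain carbon, four bonds along the chain from an oxygen on an aromatic ring, and dipentylamino in place of (dibutylamino)methyl on a saturated chain carbon, four bonds along the chain from an oxygen on an aromatic ring counts that change. Going by the values given here, the one measured step bearing on it, a 2.6-fold higher number from compound 1 to compound 2 (0.42 log units; beyond the scatter) for dibutylamino in place of dipropylamino, is modest. A similar rise is expected, with an estimated 2.4-fold higher number from compound 2 to compound 3 (0.37 log units; beyond the scatter) in this assay as its likely size. Compound 3 is expected at 16000 nM with 6000 nM to 40000 nM as its estimated range.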

Compound 3, half-maximal inhibitory concentration: 7900 nM
Compound 3: the middle estimate sits 2.0-fold (0.31 log units) above what was measured; the range from low to high includes it.
By their numbers in this assay, from the lowest: compound 1; then compounds 2 and 3 (each within the scatter of the next).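

In this assay, dipentylamino in place of (dibutylamino)methyl gives a 1.2-fold higher number from compound 2 to compound 3 (0.07 log units; within the scatter) and so does not separate these two compounds, unlike the earlier step on the amine arms. The change from the dipropylamino compound, a 3.0-fold higher number from compound 1 to compound 3 (0.48 log units; beyond the scatter) here, leaves compound 1 with the lowest number of the three. Nothing measured here explains this result.

Still open, on these data alone, is how a ring amine such as piperidine or a smaller dimethylamino group would read at this place. As far as these compounds go, a longer chain carrying these amines is also open.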